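Cyclopropyl Ketone to Isopropyl Amide on a Thiophene Core

A few compounds are considered here, and "the series" means these few. Any claim that something is new, unique, unknown or untested is made for them only; others in the source may bear on it.

Measured compounds:
compound 1, `CC1=C(C(=O)C2CC2)C(c2cccs2)NC(=O)N1`: 15%
compound 2, `CC1=C(C(=O)C2CC2)C(c2ccsc2)NC(=O)N1`: 1%

In an assay on membranes from HeLa cells for displacement of a labelled ligand from adenosine receptor A3 (Homo sapiens), read by scintillation counting, with a stated time of 180 min, tested at 1 uM (a lower number here means less inhibition, a higher number more inhibition at the concentration tested (going by the name of the read-out)), compound 1 gives 15%, the higher of the two numbers recorded. Its nearest neighbour is compound 2, which differs only by thiophen-3-yl in place of thiophen-2-yl on a saturated ring carbon and gives 1%; the step of a number 14 percentage points lower from compound 1 to compound 2 (beyond the scatter) lies beyond the scatter and is of modest size.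

Compound 3, `CC1=C(C(=O)NC(C)C)C(c2cccs2)NC(=O)N1`, is not yet measured. It differs from compound 1 at a different place, the carbonyl carbon: isopropylamino in place of cyclopropyl on a carbonyl carbon

Among the compounds with values here, the only measured step concerns the thiophene attachment and not the carbonyl substituent, so no recorded step bears directly on this change. What is known is that the shared core with thiophen-2-yl reaches only a low level of inhibition in compound 1, and a modest change elsewhere already reduced it in compound 2. The step of a number 5 percentage points lower from compound 1 to compound 3 (within the scatter) is therefore expected to be small, within or only just beyond the scatter, with no direction firmly indicated. For compound 3 the value in this assay is estimated at 10%, with a range from 0% to 30%.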

Compound 3, a percentage reported as inhibition, at one concentration (the size of the read-out at that concentration, not a potency): 1%
The estimate for compound 3 lay 9 percentage points above the measured number; the measured number falls inside the stated range.
By their numbers in this assay, from the lowest: compounds 2 and 3 (each within the scatter of the next); then compound 1.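

In this assay the carbonyl carbon proves to be a place where the number responds: isopropylamino in place of cyclopropyl gives a number 14 percentage points lower from compound 1 to compound 3 (beyond the scatter) and is a modest step. Until now only the thiophene attachment had been seen to move the number, so compound 1 now has two single changes, at two different places, and each leads to a lower number. Nothing shown here accounts for the lower number with isopropylamino, which brings a nitrogen and a hydrogen-bond donor and removes the three-membered ring.

The change from cyclopropyl to isopropylamino alters several things at once, so these compounds leave open whether the lower number goes with the nitrogen on the carbonyl carbon or with the loss of the ring; a cyclopropylamino group or an isopropyl ketone on the same core would separate the two. Going by these compounds, it also remains open whether any group at this carbonyl carbon, such as a longer chain or a morpholine amide, would lift the number above that of compound 1 in this assay.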